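A second fluoro on compound 2

The compounds below may be only part of what the source reports. "The series", "measured", "known", "first", "only" and "open" are said of these compounds alone.

Compound 1 `Nc1ccn([C@H]2C=C[C@@H](CO)O2)c(=O)n1` gives 65000 nM
Compound 2 `Nc1ccn([C@H]2C=C(F)[C@@H](CO)O2)c(=O)n1` gives > 100000 nM

In a functional assay on cells (Homo sapiens) for cytotoxicity (a lower number here means a stronger inhibitor, a higher number a weaker inhibitor), compound 1 gives 65000 nM as a measured number. Compound 2 gives > 100000 nM there, which is a limit and not a number. Compound 3 `Nc1nc(=O)n([C@H]2C=C(F)[C@@H](CO)O2)cc1F` differs from compound 2 by fluoro in place of hydrogen on an aromatic carbon in one place, fluoro in place of hydrogen on an aromatic carbon. Among the compounds with values here, the one measured step bearing on this is an at least 1.5-fold higher number from compound 1 to compound 2 (0.18 log units; that floor lies within the scatter) and it also put fluoro in place of hydrogen, there on a double-bonded ring carbon. No step beyond the scatter is therefore expected in this assay in either direction. The expected step is a number no higher from compound 2 to compound 3 (the limit leaves the size open) and another limit is likely. Compound 3 is estimated at 100000 nM with a range of 30000 nM to 300000 nM overall.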

Compound 3, half-maximal inhibitory concentration: > 100000 nM
Compound 3 was reported as a limit; the forecaster's own chance of this, stated with the estimate: 70%; the middle value lies on the limit itself.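

Compound 2 and compound 3 are both reported only as limits in this assay, so no step can be read between them: the limit of > 100000 nM in this assay, at which 2 of the 3 values shown sit.

Going by these compounds, whether the fluoro on the aromatic carbon changes the result at all, and by how much, stays open.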